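Does Trifluoromethyl Keep the Difluoro Gain?

This account rests on a few compounds, and the source may have more. Where it says the series, first, only, none or still open, it means among the compounds named here.

In a functional assay on MV4-11 cells (Homo sapiens) for antiproliferative activity, read by luminescence and CellTiter-Glo, with a stated time of 72 h (on this read-out higher numbers stand for weaker inhibition and lower numbers for stronger inhibition), compound 1 `CNc1cc(-c2ccc3cnn(Cc4ccc(F)cc4)c3c2)cn(C)c1=O` gives 2390 nM and compound 2 `CNc1cc(-c2ccc3cnn(Cc4ccc(OC)cc4)c3c2)cn(C)c1=O` gives 2700 nM while compound 3 `CNc1cc(-c2ccc3cnn(Cc4ccc(F)c(F)c4)c3c2)cn(C)c1=O` gives 320 nM as the lowest of the three numbers, which makes it the strongest inhibitor so far.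

Compound 4 `CNc1cc(-c2ccc3cnn(Cc4ccc(C(F)(F)F)cc4)c3c2)cn(C)c1=O` has not been measured yet. It differs from compound 3 in one place, on a saturated chain carbon bound to an aromatic nitrogen, where 4-(trifluoromethyl)phenyl stands in place of 3,4-difluorophenyl (4-(trifluoromethyl)phenyl in place of 3,4-difluorophenyl on a saturated chain carbon bound to an aromatic nitrogen).

Two sizeable steps led to the 3,4-difluorophenyl group: adding a fluoro gave a 7.5-fold lower number from compound 1 to compound 3 (0.87 log units; beyond the scatter) and replacing 4-methoxyphenyl gave an 8.4-fold lower number from compound 2 to compound 3 (0.93 log units; beyond the scatter) in the same direction. Methoxy in place of fluoro, by contrast, gave a 1.1-fold higher number from compound 1 to compound 2 (0.05 log units; within the scatter) and so showed no real change. Among the compounds with values here, compound 4 also lacks the 3,4-difluorophenyl group, so its number is expected to move back toward those of compound 1 and compound 2, although no trifluoromethyl compound has been measured yet.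

The expected size is a 4.7-fold higher number from compound 3 to compound 4 (0.67 log units; beyond the scatter) in this assay toward weaker inhibition, somewhat short of the two large steps. For compound 4 the estimated value is 1500 nM with an expected range from 400 nM to 4000 nM to allow for the untested group.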

Compound 4, half-maximal inhibitory concentration: 4370 nM
The estimate for compound 4 lay 2.9-fold (0.46 log units) below the measured number, outside the stated range (above it).
By their numbers in this assay, from the lowest: compound 3; then compounds 1, 2 and 4 (each within the scatter of the next).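

In this assay, 4-(trifluoromethyl)phenyl in place of 3,4-difluorophenyl on the saturated chain carbon bound to an aromatic nitrogen gives a 14-fold higher number from compound 3 to compound 4 (1.14 log units; beyond the scatter), so the gain seen with compound 3 does not carry over to this group, even though it also contains fluorine. Compound 4 instead falls level with the other two compounds, with a 1.6-fold higher number from compound 2 to compound 4 (0.21 log units; within the scatter) and a 1.8-fold higher number from compound 1 to compound 4 (0.26 log units; within the scatter), so fluoro, methoxy and trifluoromethyl cannot be told apart here, and among these four compounds only the one with 3,4-difluorophenyl stands out. Nothing available here explains why this position responds in this way.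

On these data alone, it remains open whether the gain depends on having both fluorines: a 3-fluorophenyl group on its own could behave like compound 3 or like the other three compounds. As far as these compounds go, it is equally open whether a 3,4-dichlorophenyl group, with chlorine in place of each fluorine, would keep the lower number, or whether a nitrile or an amine on this ring would fall with compound 4.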